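A few compounds are considered here, and "the series" means these few. Any claim that something is new, unique, unknown or untested is made for them only; others in the source may bear on it.

The series is built on a common ketone of a long unsaturated chain, and the compounds are compared in an assay on isolated protein for inhibition of Fatty-acid amide hydrolase 1 (Homo sapiens); a lower number here means a stronger inhibitor, a higher number a weaker inhibitor. Compound 1 `CCCCCCCC/C=C\CCCCCCC(=O)c1ccccc1` carries a phenyl on the carbonyl carbon. In this assay compound 1 gives only a limit, > 100000 nM, and no number. Compound 2 `CCCCCCCC/C=C\CCCCCCC(=O)c1ncc(-c2ccoc2)o1` carries a different heteroaromatic group on the carbonyl carbon; in this assay compound 2 gives 610 nM. Compound 3 `CCCCCCCC/C=C\CCCCCCC(=O)c1nnn(C)n1` has not yet been measured; it differs from compound 1 by 2-methyl-2H-tetrazol-5-yl in place of phenyl on a carbonyl carbon. Within the data shown here, no measured step connects compound 1 to another compound, and compound 1 sits at the limit of > 100000 nM in this assay, at which 1 of the 2 values shown sits, so the size of the step can only be framed by where compound 2 stands. A step toward stronger inhibition in this assay is expected, of the size an at least 50-fold lower number from compound 1 to compound 3 (1.69 log units; beyond the scatter). The value of compound 3 in this assay is estimated at 2000 nM, with a range from 400 nM to 10000 nM.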

Compound 3, inhibition constant: 65 nM
The estimate for compound 3 lay 31-fold (1.49 log units) above the measured number, and the stated range ends above it.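

Replacing phenyl with 2-methyl-2H-tetrazol-5-yl on a carbonyl carbon gives an at least 1500-fold lower number from compound 1 to compound 3 (3.18 log units; beyond the scatter) in this assay, and the count of heavy atoms on that carbon stays the same while carbon gives way to nitrogen and hydrogen-bond acceptors enter. Compound 2 had already given a measured number with a different heteroaromatic group at this place, but only compound 3 ties a gain to a change that adds no heavy atoms. The step is a lower bound only, because compound 1 gives a limit and not a number: the limit of > 100000 nM in this assay, at which 1 of the 3 values shown sits.

The compounds shown leave open which part of the 2-methyl-2H-tetrazol-5-yl group carries the gain, since no close relative of it appears here. An ethyl or a carboxylic acid in place of the methyl, or a saturated chain in place of the unsaturated one, would test how far this result extends.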